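This account rests on a few compounds, and the source may have more. Where it says the series, first, only, none or still open, it means among the compounds named here.

Working notes on the series, starting from the two compounds already measured.

Compound 1 `CCCCCCCCCCCCCCC1(C(=O)NCCO)CO1` gives 100 mg/kg in a functional assay on the whole organism with Rattus norvegicus as the target, in the glucose tolerance test; on this read-out higher numbers stand for an effect only at larger amounts of compound and lower numbers for an effect already at smaller amounts. Among the compounds with values here, compound 2 `CCCCCCCCCCCCCCC1(C(N)=O)CO1` gives 10 mg/kg in this assay, the lowest of the two numbers so far; the single step, a 10-fold lower number from compound 1 to compound 2 (1.00 log units; beyond the scatter), came from hydrogen in place of 2-hydroxyethyl on an amide-type nitrogen.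

The next compound, compound 3 `CCCCCCCCCCCCCCC1(C(=O)N(C)C)CO1`, is not yet measured. It differs from compound 2 by dimethylamino in place of amino on a carbonyl carbon. Within the data shown here, the only step that bears on this is a 10-fold lower number from compound 1 to compound 2 (1.00 log units; beyond the scatter): removing a substituent from the amide-type nitrogen lowered the number beyond the scatter. Compound 3 goes the other way on that nitrogen, dimethylamino in place of amino, so the expected direction is a higher number in this assay, though the substituent is not the same as in compound 1 and the size is uncertain.

Compound 3 is therefore estimated at 30 mg/kg in this assay, within the range 10 mg/kg to 100 mg/kg, the expected step from compound 2 being a 3.0-fold higher number from compound 2 to compound 3 (0.48 log units; beyond the scatter).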

Compound 3, minimum effective dose: 25 mg/kg
Estimate against measurement, compound 3: 1.2-fold (0.08 log units) above; the measured number falls inside the stated range.
By their numbers in this assay, from the lowest: compound 2; then compound 3; then compound 1.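

In this assay, both substituted amides now stand above the unsubstituted carbamoyl of compound 2, and no compound shown goes against this: dimethylamino in place of amino on the carbonyl carbon gives a 2.5-fold higher number from compound 2 to compound 3 (0.40 log units; beyond the scatter), so the rise seen with 2-hydroxyethyl is not confined to that one substituent. The substituents on this nitrogen also differ from each other, with a 4.0-fold lower number from compound 1 to compound 3 (0.60 log units; beyond the scatter), so the position responds to which group is present and not only to whether the nitrogen is substituted. No measurement here accounts for either step.

The compounds shown do not separate the effect of a single substituent on this nitrogen from that of two, so a methylamino group on the same carbonyl carbon, or a 2-hydroxyethyl group paired with a methyl group, would be the direct comparison. They also leave open how a carboxylic acid in place of the carbamoyl group would read in this assay, and whether the order of the amides holds with a shorter alkyl chain on the shared core.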